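This account rests on a few compounds, and the source may have more. Where it says the series, first, only, none or still open, it means among the compounds named here.

Compound 2 `CC(=O)Nc1ccc(-c2nc3cc(C(F)(F)F)ccc3n2C2CCCCC2)cc1` was examined in an ADME assay on MT4 cells (Homo sapiens) for cytotoxicity, read by MTT assay, with a stated time of 96 h (on this read-out higher numbers stand for lower toxicity in this test and lower numbers for higher toxicity in this test), where it gives 24000 nM. That is the highest of the two numbers recorded so far. For the measured compounds named here, the only other measured compound is compound 1 `COc1ccc(-c2nc3cc(C(F)(F)F)ccc3[nH]2)cc1`, which in this assay gives 2000 nM, a number well beyond the usual scatter below that of compound 2. Compound 3 `CC(=O)Nc1ccc(-c2nc3cc(C(F)(F)F)ccc3[nH]2)cc1` is not yet measured. It differs from compound 2 in one place: hydrogen in place of cyclohexyl on an aromatic nitrogen. Going by the values given here, no measured pair shows this same change, so its effect can only be judged from the two numbers available. Compound 1 also carries a hydrogen on that aromatic nitrogen and sits far lower, so the change is expected to move the number downward rather than leave it within the scatter. The step from compound 2 to compound 3 is estimated as a 4.8-fold lower number from compound 2 to compound 3 (0.68 log units; beyond the scatter). On that basis compound 3 is expected to give about 5000 nM in this assay, somewhere between 1500 nM and 16000 nM.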

Compound 3, half-maximal cytotoxic concentration: 19000 nM
Beside the measured number, compound 3's estimate is 3.8-fold (0.58 log units) below it; measured number above the stated range.
By their numbers in this assay, from the lowest: compound 1; then compounds 3 and 2 (each within the scatter of the next).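

In this assay the swap of cyclohexyl for hydrogen on the aromatic nitrogen gives a 1.3-fold lower number from compound 2 to compound 3 (0.10 log units; within the scatter), so compound 2 and compound 3 cannot be told apart, and this large ring on the nitrogen makes no measurable difference here when acetamido is present. With hydrogen on that nitrogen in both compounds, acetamido in place of methoxy on an aromatic carbon gives a 9.5-fold higher number from compound 1 to compound 3 (0.98 log units; beyond the scatter), so the low number of compound 1 does not come from the hydrogen alone and goes with this single swap. No measurement shown here explains either result.

Going by these compounds, whether a methyl or a benzyl group on the same nitrogen would also leave the number unmoved remains open. So does the outcome with an amine or a hydroxyl group in place of acetamido on the aromatic carbon.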